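A shared limit and one compound still to be measured

A few compounds are considered here, and "the series" means these few. Any claim that something is new, unique, unknown or untested is made for them only; others in the source may bear on it.

Compound 1 `FC(F)=C(F)CCSc1nccs1`, compound 2 `FC(F)=C(F)CCSc1ncc(-c2ccncc2)s1`, compound 3 `O=S(=O)(CCC(F)=C(F)F)c1ncc(-c2ccncc2)s1` and compound 4 `O=S(=O)(CCC(F)=C(F)F)c1nccs1` make up this set; compound 4 has not yet been measured.

In a functional assay on MCF7 cells (Homo sapiens) for cytotoxicity, read by MTT assay, with a stated time of 48 h (a higher number here means a weaker inhibitor, a lower number a stronger inhibitor), compound 1 gives > 120000 nM, which is a limit of the assay and not a number. In this assay compound 2 gives > 120000 nM, again a limit. In this assay compound 3 gives > 120000 nM, also a limit. The three measured values share one feature: the limit of > 120000 nM in this assay, at which 3 of the 3 values shown sit.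

From compound 2 to compound 1 the change is hydrogen in place of pyridin-4-yl on an aromatic carbon. The step it made, a step that the two limits leave unreadable from compound 2 to compound 1, cannot be read, since both ends are limits. From compound 3 to compound 4 the change is hydrogen in place of pyridin-4-yl on an aromatic carbon. It is the same kind of change, not the same, since around the place the ring atom bears a group of 8 heavy atoms in compound 2 and a large group in compound 3. How the cores of compound 2 and compound 3 differ is not broken down here.

For compound 4 in this assay the step that the limit leaves unreadable from compound 3 to compound 4 is expected to be small, because compound 3 sits at > 120000 nM and the limit of > 120000 nM in this assay, at which 3 of the 3 values shown sit, holds for every measured value. Compound 4 is therefore estimated at 150000 nM, most likely reported as a limit, with the expectation spanning 100000 nM to 400000 nM.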

Compound 4, half-maximal inhibitory concentration: > 120000 nM
Compound 4: a limit, no number; the forecaster's own chance of this, stated with the estimate: 90%; the middle value does not contradict the limit.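

In this assay compound 4 gives > 120000 nM, a limit of the assay and not a number. The step from compound 3 to compound 4 therefore cannot be read, and one feature runs through the whole set: the limit of > 120000 nM in this assay, at which 4 of the 4 values shown sit.

The compounds shown leave open what value any of them has in this assay, and whether hydrogen in place of pyridin-4-yl changes that value at all.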